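Swapping the phenol ring in a thioether enone series

The source may report more compounds than this note shows. Statements on the series, on what has been measured and on what is new or still open speak of the compounds shown alone.

Compounds measured so far:
compound 1 `O=C(/C(=C\c1ccc(O)c([N+](=O)[O-])c1)SCc1ccc(Cl)cc1)c1ccc(Cl)cc1` — 10000 nM
compound 2 `O=C(/C(=C\c1ccc(O)c([N+](=O)[O-])c1)SCc1ccccc1Cl)c1ccc(Cl)cc1` — 10000 nM
compound 3 `O=C(/C(=C\c1ccc(O)c([N+](=O)[O-])c1)Sc1ccccc1Br)c1ccc(Cl)cc1` — 25000 nM

In a functional assay on DU-145 cells (Homo sapiens) for inhibition, read by trypan blue exclusion, with a stated time of 96 h (a higher number here means a weaker inhibitor of growth, a lower number a stronger inhibitor of growth), compound 1 gives 10000 nM, level with compound 2 and together the lowest of the three numbers; compound 3 lies furthest, with a 2.5-fold higher number from compound 1 to compound 3 (0.40 log units; beyond the scatter). Compound 4 `CSc1ccc(/C=C(/SCc2ccc(Cl)cc2)C(=O)c2ccc(Cl)cc2)cc1` differs from compound 1 in one place: 4-(methylsulfanyl)phenyl in place of 4-hydroxy-3-nitrophenyl on a double-bonded chain carbon bound to a double-bonded chain carbon. Within the data shown here, none of the measured steps touches this position; no change at the digits printed from compound 1 to compound 2 (within the scatter) and a 2.5-fold higher number from compound 2 to compound 3 (0.40 log units; beyond the scatter) concern only the group on the sulfur, so they offer no guide to the size or direction of this change. Compound 4 is therefore expected to stay near compound 1, with a 1.2-fold higher number from compound 1 to compound 4 (0.08 log units; within the scatter) and a wide range, estimated at 12000 nM between 3000 nM and 40000 nM.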

Compound 4, concentration for 50% growth inhibition: 25000 nM
Compound 4: middle estimate off by 2.1-fold (0.32 log units), on the low side, within the range that was stated.
By their numbers in this assay, from the lowest: compounds 1 and 2 (each within the scatter of the next); then compounds 3 and 4 (each within the scatter of the next).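

In this assay, putting 4-(methylsulfanyl)phenyl in place of 4-hydroxy-3-nitrophenyl gives a 2.5-fold higher number from compound 1 to compound 4 (0.40 log units; beyond the scatter), which shows that the group on this double-bonded chain carbon can shift the number, something the changes on the sulfur could not show. The change removes the hydroxy and nitro groups together, and the hydrogen-bond donor count of the group falls from 1 to 0. Nothing measured here accounts for the step. The compounds shown leave open whether the loss of the hydroxy or of the nitro group matters more. They also leave open how a phenyl ring carrying an amine or a carboxylic acid would behave at this place.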